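The source may report more compounds than this note shows. Statements on the series, on what has been measured and on what is new or still open speak of the compounds shown alone.

Compound 2 `COc1ccc2c(c1)OC(c1cc(OC)c(OC)c(OC)c1)C(C(=O)NC(C)C)=C2` carries an isopropylcarbamoyl group on the shared core, where compound 1 `COc1ccc2c(c1)OC(c1cc(OC)c(OC)c(OC)c1)C(C=O)=C2` carries an aldehyde. In a functional assay for inhibition of nuclear factor NF-kappa-B complex (Homo sapiens) (a lower number here means a stronger inhibitor, a higher number a weaker inhibitor), compound 1 gives 13500 nM. In this assay compound 2 gives > 50000 nM, which is a limit of the assay and not a number. So compound 2 stands at the weak end of what has been measured, and the step of an at least 3.7-fold higher number from compound 1 to compound 2 (0.56 log units; beyond the scatter) is known only as a bound because of the limit of > 50000 nM in this assay, at which 1 of the 2 values shown sits. Compound 3 `COc1ccc2c(c1)OC(c1cc(OC)c(OC)c(OC)c1)C=C2` has not yet been measured in this assay; it differs from compound 2 by hydrogen in place of isopropylcarbamoyl on a double-bonded ring carbon. Going by the values given here, the only measured step that bears on this change is the one from compound 1 to compound 2, and it shows that enlarging the group on that carbon weakened inhibition to the limit; removing the group entirely goes the other way, but no measured pair shows what the bare core does. The step of an at least 1.6-fold lower number from compound 2 to compound 3 (0.22 log units; that floor lies within the scatter) is therefore expected to be small or to lead to a somewhat lower number, and compound 3 is estimated at 30000 nM, within a range of 8000 nM to 150000 nM.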

Compound 3, half-maximal inhibitory concentration: 17700 nM
Compound 3: middle estimate off by 1.7-fold (0.23 log units), on the high side; the range from low to high includes it.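

In this assay, taking isopropylcarbamoyl off the double-bonded ring carbon returns the series to a measurable value, and the step of an at least 2.8-fold lower number from compound 2 to compound 3 (0.45 log units; beyond the scatter) is known only as a bound: the limit of > 50000 nM in this assay, at which 1 of the 3 values shown sits. Compound 2 stands at > 50000 nM, which is a limit of the assay and not a number. The step of a 1.3-fold higher number from compound 1 to compound 3 (0.12 log units; within the scatter) means that hydrogen and formyl on this carbon cannot be told apart in this assay, so among the three compounds shown the weakening appears only with isopropylcarbamoyl, and inhibition at this level does not depend on the aldehyde.

On these data alone, what a primary carboxamide, a carboxylic acid or a methyl ester would do on this carbon remains open, and with it whether the weakening goes with the amide as such or with its isopropyl part. Also open, as far as these compounds go, is whether any group here, an aminomethyl group for instance, can give a clearly lower number than hydrogen does.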